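The compounds below may be only part of what the source reports. "The series", "measured", "known", "first", "only" and "open" are said of these compounds alone.

Measured compounds:
Compound 1 `CCOC(=O)c1c(C)oc2nc(Nc3ccccc3)nc(N3CCC(C)CC3)c12` – 26100 nM
Compound 2 `CCCCNc1nc(Nc2ccccc2)nc2oc(C)c(C(=O)OCC)c12` – 50200 nM
Compound 3 `CCOC(=O)c1c(C)oc2nc(Nc3cccc(C)c3)nc(N3CCN(C)CC3)c12` – 18200 nM

In a functional assay on sSPC-A1 cells (Homo sapiens) for cytotoxicity, read by MTT assay, with a stated time of 48 h (on this read-out lower numbers stand for stronger inhibition and higher numbers for weaker inhibition), compound 3 gives the lowest of the three numbers, close to compound 1 and further from compound 2. Compound 4 `CCOC(=O)c1c(C)oc2nc(Nc3cccc(C)c3)nc(NC(C)C)c12` differs from compound 3 by isopropylamino in place of 4-methylpiperazin-1-yl on an aromatic carbon. Among the compounds with values here, one measured step bears on this: the exchange of a ring amine for a chain amine at the same place, which gave a 1.9-fold higher number from compound 1 to compound 2 (0.28 log units; within the scatter). On that basis the step from compound 3 to compound 4 is expected to be a 1.4-fold higher number from compound 3 to compound 4 (0.15 log units; within the scatter), a small rise not beyond the scatter. Compound 4 is therefore estimated at 26000 nM, with a range from 11000 nM to 60000 nM.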

Compound 4, half-maximal inhibitory concentration: 46300 nM
Estimate against measurement, compound 4: 1.8-fold (0.25 log units) below, and the stated range covers the measured number.
By their numbers in this assay, from the lowest: compounds 3, 1, 4 and 2 (each within the scatter of the next, the first and the last beyond it).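

In this assay, isopropylamino in place of 4-methylpiperazin-1-yl gives a 2.5-fold higher number from compound 3 to compound 4 (0.41 log units; beyond the scatter), so a chain amine for a ring amine at this place now produces a step beyond the scatter, unlike butylamino with a 1.9-fold higher number from compound 1 to compound 2 (0.28 log units; within the scatter). Within the data shown here, both steps run in the same direction, though these are only two pairs. No evidence at hand accounts for the size of the new step. The compounds shown leave open whether the ring or its second nitrogen carries the difference. Going by these compounds, how a morpholin-4-yl or cyclopropylamino group would read at this place also remains open.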